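Tetrazole for oxadiazole on a thiazole core

The source may report more compounds than this note shows. Statements on the series, on what has been measured and on what is new or still open speak of the compounds shown alone.

Compound 1 `O=C(c1sc(-c2cccc(F)c2)nc1O)N1CCCOC1` reaches only the limit of an assay on HEK293 cells for inhibition of transient receptor potential cation channel subfamily M member 8 (Homo sapiens), read by FLIPR, with stated times of 5 min and 3 min (on this read-out lower numbers stand for stronger inhibition and higher numbers for weaker inhibition), with > 100000 nM. Compound 2 `Cc1nnc(-c2sc(-c3cccc(F)c3)nc2O)o1` gives 9100 nM in this assay.

Compound 2 thus stands on the only number shown, while compound 1 sits at the limit of > 100000 nM in this assay, at which 1 of the 2 values shown sits. Compound 3 `Oc1nc(-c2cccc(F)c2)sc1-c1nn[nH]n1` differs from compound 2 by 2H-tetrazol-5-yl in place of 5-methyl-1,3,4-oxadiazol-2-yl on an aromatic carbon. Among the compounds with values here, no measured pair differing in one place is available, so the size of this step is open. A modest weakening is expected, a 2.2-fold higher number from compound 2 to compound 3 (0.34 log units; beyond the scatter), which may not exceed the usual scatter. Compound 3 is therefore estimated at 20000 nM in this assay, between 5000 nM and 80000 nM.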

Compound 3, half-maximal inhibitory concentration: > 100000 nM
Compound 3 ended at the assay's limit; the forecaster's own chance of this, stated with the estimate: 25%; at least 5.0-fold (0.69 log units) between middle value and limit.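

Placing 2H-tetrazol-5-yl in place of 5-methyl-1,3,4-oxadiazol-2-yl on the aromatic carbon next to the ring sulfur gives an at least 10-fold higher number from compound 2 to compound 3 (1.04 log units; beyond the scatter) in this assay. This first step measured at this position shows that the group held there can decide whether a number is read at all. For compound 3 the value of > 100000 nM is a limit of the assay, which it now shares with compound 1: the limit of > 100000 nM in this assay, at which 2 of the 3 values shown sit.

As far as these compounds go, how far the true step reaches stays open. Also open, from the compounds shown here alone, is how a carboxylic acid, or a tetrazole carrying a methyl on a ring nitrogen, would read at this carbon.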